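Working notes: 2-bromophenyl to 3-bromophenyl on the carbonyl carbon

The source may report more compounds than this note shows. Statements on the series, on what has been measured and on what is new or still open speak of the compounds shown alone.

Measured so far in a functional assay on SK-BR-3 cells (Homo sapiens) for antiproliferative activity, read by MTT assay, with a stated time of 72 h; on this read-out lower numbers stand for stronger inhibition and higher numbers for weaker inhibition:
- compound 1 `CCN1CCN(c2cc(C)c3cc(NC(=O)c4ccc[nH]4)ccc3n2)CC1` gives 13200 nM
- compound 2 `CCN1CCN(c2cc(C)c3cc(NC(=O)c4cccnc4)ccc3n2)CC1` gives 10600 nM
- compound 3 `CCN1CCN(c2cc(C)c3cc(NC(=O)c4ccccc4Br)ccc3n2)CC1` gives 39200 nM

Compound 3 stands highest of the three, beyond the scatter from both others. Compound 4 `CCN1CCN(c2cc(C)c3cc(NC(=O)c4cccc(Br)c4)ccc3n2)CC1` has 3-bromophenyl in place of 2-bromophenyl on a carbonyl carbon. Among the measured compounds shown here, no measured pair moves the bromine. The nearest evidence is two modest steps that bring in 2-bromophenyl: a 3.0-fold higher number from compound 1 to compound 3 (0.47 log units; beyond the scatter) and a 3.7-fold higher number from compound 2 to compound 3 (0.57 log units; beyond the scatter) on this read-out. The remaining step is a 1.2-fold lower number from compound 1 to compound 2 (0.10 log units; within the scatter) and adds little. A modest return toward lower numbers is therefore expected, although a result within the scatter of compound 3 remains possible. The expected step in this assay is a 2.2-fold lower number from compound 3 to compound 4 (0.34 log units; beyond the scatter) on this estimate. For compound 4 the estimated value is 18000 nM with an expected range of 7000 nM to 45000 nM in this assay.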

Compound 4, half-maximal inhibitory concentration: 13300 nM
For compound 4 the middle estimate is 1.4-fold (0.13 log units) above the measured one, within the range that was stated.
By their numbers in this assay, from the lowest: compounds 2, 1 and 4 (each within the scatter of the next); then compound 3.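

In this assay, 3-bromophenyl in place of 2-bromophenyl on the carbonyl carbon gives a 2.9-fold lower number from compound 3 to compound 4 (0.47 log units; beyond the scatter) with the same atoms joined differently, so the place of the bromine matters at this position, not only its presence. Compound 4 shows no separation from the other two amides, with a 1.3-fold higher number from compound 2 to compound 4 (0.10 log units; within the scatter) and a 1.0-fold higher number from compound 1 to compound 4 (0.00 log units; within the scatter) on this read-out, which leaves compound 3 alone apart from the rest. Nothing at hand gives a cause for this shift.

Still open, going by these compounds, is how an amine or a carboxylic acid in place of the bromine would read here. Also open, on these data alone, is whether any group on this carbonyl carbon reaches numbers well under those of compound 2, compound 1 and compound 4.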